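The source may hold more compounds than are shown below. What is called first, only, known or untested is meant among the compounds shown, and "the series" means these compounds.

Measured compounds:
compound 1, `O=C1C=C[C@]2(OC(=O)c3ccccc3)CCO[C@@H]2C1`: in a functional assay on P388 cells (Mus musculus) for cytotoxicity (on this read-out lower numbers stand for stronger inhibition and higher numbers for weaker inhibition), compound 1 gives 0.5 ug/mL;
compound 2, `OC1C=C[C@]2(O)CCO[C@@H]2C1`: in this assay compound 2 gives 40.8 ug/mL;
compound 3, `CCCC(=O)O[C@]12C=CC(O)C[C@H]1OCC2`: in this assay compound 3 reaches only the limit of > 100 ug/mL, which is not a number.

Compound 3 thus stands at the highest number shown, sitting on (the limit of > 100 ug/mL in this assay, at which 1 of the 3 values shown sits). Compound 4, `CCCCCCCC(=O)O[C@]12C=CC(O)C[C@H]1OCC2`, differs from compound 3 by butyl in place of hydrogen on a saturated chain carbon, three bonds along the chain from a carbonyl carbon. Among the measured compounds shown here, the only measured step, an at least 2.4-fold higher number from compound 2 to compound 3 (0.38 log units; beyond the scatter), ended at that limit, and no measured pair tests a longer chain of this kind, so it bears on the change only loosely. The change from compound 3 to compound 4 is expected to be a number no higher from compound 3 to compound 4 (the limit leaves the size open), nothing beyond the scatter. Compound 4 is expected to give about 100 ug/mL in this assay, between 30 ug/mL and 300 ug/mL, and most likely again only a limit.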

Compound 4, half-maximal inhibitory concentration: 8.4 ug/mL
The estimate for compound 4 lay 12-fold (1.08 log units) above the measured number; measured number outside the range, below it.
By their numbers in this assay, from the lowest: compound 1; then compound 4; then compound 2. At a limit, above all of these: compound 3.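

Within this assay butyl in place of hydrogen on a saturated chain carbon, three bonds along the chain from a carbonyl carbon, gives an at least 11-fold lower number from compound 3 to compound 4 (1.07 log units; beyond the scatter) and so shows that the length of this chain matters. Among the compounds shown here, no earlier pair tested this, and here the longer chain moves the number towards stronger inhibition. The full size of the step cannot be read because compound 3 gives only a limit: the limit of > 100 ug/mL in this assay, at which 1 of the 4 values shown sits.

From the compounds shown here alone, whether a longer chain would lower the number further remains open. So does whether a chain ending in an amine or a carboxylic acid would keep this gain.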